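Urea series: fluoromethyl branched to 1-fluoroethyl

The source may hold more compounds than are shown below. What is called first, only, known or untested is meant among the compounds shown, and "the series" means these compounds.

Compound 2 `CNc1cc(Oc2ccc(NC(=O)Nc3cccc(CF)c3)cc2)ncn1` gives 400 nM in an assay on isolated protein for inhibition of serine/threonine-protein kinase TNNI3K (Homo sapiens) (a lower number here means a stronger inhibitor, a higher number a weaker inhibitor), the highest of the two numbers recorded so far. Compound 3 `CNc1cc(Oc2ccc(NC(=O)Nc3cccc(C(F)(F)F)c3)c(F)c2F)ncn1` gives 20 nM in this assay, a gap from compound 2 that lies beyond the scatter. Compound 1 `CCc1cc(NC(=O)Nc2cccc(C(F)(F)F)c2)cc(Cl)c1Oc1cc(NC)ncn1` reaches only a limit, <= 10 nM in this assay, so no number is known for it. Note (the limit of <= 10 nM in this assay, at which 1 of the 3 values shown sits). Compound 4 `CNc1cc(Oc2ccc(NC(=O)Nc3cccc(C(C)F)c3)cc2)ncn1` is not yet measured. It differs from compound 2 by methyl in place of hydrogen on a saturated chain carbon bound to an aromatic carbon and a fluorine atom. Among the measured compounds shown here, no measured pair carries this change, so its size is uncertain; a step within the scatter is expected, if anything toward a lower number. Compound 4 is expected to give 250 nM in this assay, within 70 nM to 900 nM. The expected step is a 1.6-fold lower number from compound 2 to compound 4 (0.20 log units; within the scatter).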

Compound 4, half-maximal inhibitory concentration: 79 nM
For compound 4 the middle estimate is 3.2-fold (0.50 log units) above the measured one; the range from low to high includes it.
By their numbers in this assay, from the lowest: compound 3; then compound 4; then compound 2. At a limit, below all of these: compound 1.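

In this assay methyl in place of hydrogen on the saturated chain carbon gives a 5.1-fold lower number from compound 2 to compound 4 (0.70 log units; beyond the scatter) and this lies beyond the scatter. Among the compounds shown here, as the only single-place step so far, it shows that the number responds to a change at this carbon, and that fluoromethyl to 1-fluoroethyl moves it toward a stronger inhibitor. Nothing shown here gives a cause for this step.

On these data alone, whether a longer chain on this carbon, such as ethyl, extends the step remains open. So does the effect of a hydroxyl group in place of the fluorine.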